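Swapping Methoxyphenyl for Nitrophenyl on a Shared Core

A few compounds are considered here, and "the series" means these few. Any claim that something is new, unique, unknown or untested is made for them only; others in the source may bear on it.

Compound 1 `COc1ccccc1N1CCN(C(=O)/C=C/c2ccc(O)c(O)c2)CC1` and compound 2 `COc1cccc(N2CCN(C(=O)/C=C/c3ccc(O)c(O)c3)CC2)c1` share one core and differ only in bearing 2-methoxyphenyl or 3-methoxyphenyl on an amine nitrogen in a ring. In a functional assay on A549 cells (Homo sapiens) for antiproliferative activity, read by MTT assay, with a stated time of 48 h (on this read-out lower numbers stand for stronger inhibition and higher numbers for weaker inhibition), compound 1 gives 0.98 ug/mL as its result and compound 2 gives 1.27 ug/mL as its result, so compound 2 stands level with compound 1 within the scatter. Compound 3 `O=C(/C=C/c1ccc(O)c(O)c1)N1CCN(c2ccc([N+](=O)[O-])cc2)CC1` brings a different kind of change, with 4-nitrophenyl in place of 3-methoxyphenyl on an amine nitrogen in a ring, and the count 4-nitrophenyl in place of 3-methoxyphenyl on an amine nitrogen in a ring sets it out in full. Within the data shown here, no measured compound carries 4-nitrophenyl, so the data offer only an indirect guide. Among the measured compounds shown here, with a 1.3-fold higher number from compound 1 to compound 2 (0.11 log units; within the scatter) as the only measured step, nothing points in either direction, and no step beyond the scatter is expected, although the uncertainty is wide. The step expected in this assay is a 1.1-fold higher number from compound 2 to compound 3 (0.04 log units; within the scatter) as an estimate. For compound 3 the estimate is 1.4 ug/mL as the middle value, with an expected range running from 0.6 ug/mL at the low end to 3.5 ug/mL at the high end.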

Compound 3, half-maximal inhibitory concentration: 1.56 ug/mL
Compound 3: the middle estimate sits 1.1-fold (0.05 log units) below what was measured, and the stated range covers the measured number.
By their numbers in this assay, from the lowest: compounds 1, 2 and 3 (each within the scatter of the next).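

In this assay, 4-nitrophenyl in place of 3-methoxyphenyl on the amine nitrogen in the ring gives a 1.2-fold higher number from compound 2 to compound 3 (0.09 log units; within the scatter), and the same group in place of 2-methoxyphenyl gives a 1.6-fold higher number from compound 1 to compound 3 (0.20 log units; within the scatter). The earlier pair only compared two methoxyphenyl groups, whereas these steps bring in a group of a different kind, with a nitro group on the aromatic ring, and the read-out still stays level among all three compounds. So, for these three compounds, this spot on the shared core accepts all three groups without a step beyond the usual scatter, although no information here explains why the numbers stay level.

Because the nitro group differs from the methoxy groups in both identity and name-given ring location, these three compounds cannot separate the effect of the group from the effect of where it sits on the aromatic ring. They also leave open whether the same level result would hold for an unsubstituted phenyl ring, or for a ring carrying an amine or a carboxylic acid, and whether it would hold in other cell lines.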